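The compounds below may be only part of what the source reports. "The series", "measured", "known", "first", "only" and "open" are said of these compounds alone.

Working notes on the series. In an assay on isolated protein for inhibition of leukotriene B4 receptor (Homo sapiens) (a lower number here means a stronger inhibitor, a higher number a weaker inhibitor), compound 1 `CCCc1cc(Oc2ccc(C(=O)O)cc2)ccc1OCCCOc1cc(O)c(C(C)=O)cc1CC` gives 330 nM, the highest number among the three measured compounds. Compound 3 `CCc1cc(C(C)=O)c(O)cc1OCCCOc1ccc(Oc2ccc(C(=O)O)cc2)cc1` gives 190 nM in this assay, and the step of a 1.7-fold lower number from compound 1 to compound 3 (0.24 log units; within the scatter) is small. Among the measured compounds shown here, compound 2 `CCCc1c(OCCCOc2cc(O)c(C(C)=O)cc2CC)cccc1Oc1ccccc1C(=O)O` gives 24 nM in this assay; no single-change step connects it to compound 1, so only the two values themselves can be set side by side.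

Compound 4 `CCCc1cc(Oc2cccc(C(=O)O)c2)ccc1OCCCOc1cc(O)c(C(C)=O)cc1CC` differs from compound 1 by 3-carboxyphenyl in place of 4-carboxyphenyl on an oxygen on an aromatic ring. For the measured compounds named here, no measured step touches the carboxyphenyl group: the one step in hand, from compound 1 to compound 3, alters the propyl group on the other end of the molecule and stays within the scatter, so it says nothing about moving the carboxylic acid. The expectation for this assay is therefore a step of a 1.7-fold lower number from compound 1 to compound 4 (0.22 log units; within the scatter) that may not rise beyond the scatter, with wide uncertainty in either direction. The estimate for compound 4 in this assay is 200 nM, with a range from 50 nM to 800 nM.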

Compound 4, half-maximal inhibitory concentration: 160 nM
For compound 4 the middle estimate is 1.3-fold (0.10 log units) above the measured one, and the stated range covers the measured number.
By their numbers in this assay, from the lowest: compound 2; then compounds 4, 3 and 1 (each within the scatter of the next, the first and the last beyond it).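

The change from 4-carboxyphenyl to 3-carboxyphenyl on an oxygen on an aromatic ring gives, in this assay, a 2.1-fold lower number from compound 1 to compound 4 (0.31 log units; beyond the scatter). Among the compounds shown here, this is the first reading at this position, and it shows that moving the carboxylic acid around the ring, with the atoms unchanged, can shift the number modestly, though only just past the scatter. Nothing measured in the series bears on the reason for this step.

For the compounds shown here, compound 2, at 24 nM, is linked by no single-change step to compound 1 or compound 4, so its much lower number cannot be assigned to any one part of its structure. Also open, as far as these compounds go, is whether an acetic acid side chain or a tetrazole would be tolerated in place of the carboxylic acid on the 3-carboxyphenyl group.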